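Methoxy for Chloro: A Second Look at One Swap

This account rests on a few compounds, and the source may have more. Where it says the series, first, only, none or still open, it means among the compounds named here.

Compound 1, `NC(=O)c1cc(-c2cccc(OC(=O)NC3CCCCC3)c2)n(-c2ccc(Cl)cc2)n1`, was tested in an assay on isolated protein for inhibition of Fatty-acid amide hydrolase 1 (Homo sapiens), read by fluorescence, with a stated time of 30 min (on this read-out lower numbers stand for stronger inhibition and higher numbers for weaker inhibition), where compound 1 gives 174 nM. Compound 2, `COc1ccc(-n2nc(C(N)=O)cc2-c2cccc(OC(=O)NC3CCCCC3)c2)cc1`, differs from compound 1 in one place: methoxy in place of chloro on an aromatic carbon. In this assay compound 2 gives 743 nM, and the step of a 4.3-fold higher number from compound 1 to compound 2 (0.63 log units; beyond the scatter). Compound 3, `CCOC(=O)c1cc(-c2ccc(OC(=O)NC3CCCCC3)cc2)nn1-c1ccc(Cl)cc1`, belongs to the same study, and in this assay compound 3 gives 586 nM; the difference between the core of compound 3 and the core of compound 1 is not broken down here, and the values of compound 3 and compound 2 lie within the scatter of each other.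

Compound 4, `CCOC(=O)c1cc(-c2ccc(OC(=O)NC3CCCCC3)cc2)nn1-c1ccc(OC)cc1`, has not yet been measured. It differs from compound 3 in one place: methoxy in place of chloro on an aromatic carbon. Among the compounds with values here, the surroundings of the place are described in the same words for both pairs, so this is the same change as the one from compound 1 to compound 2, carried onto another core. Within the data shown here, that earlier step is the only guide available for compound 4. Because the step of a 4.3-fold higher number from compound 1 to compound 2 (0.63 log units; beyond the scatter) was modest and beyond the scatter, the number for compound 4 is expected to rise by an estimated step of a 3.1-fold higher number from compound 3 to compound 4 (0.49 log units; beyond the scatter). From the compounds shown here alone, whether the second core carries the change to the same degree is unknown, so the expectation is held loosely. For compound 4 in this assay the estimated value is 1800 nM, expected to fall between 800 nM and 4500 nM.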

Compound 4, half-maximal inhibitory concentration: 159 nM
The estimate for compound 4 lay 11-fold (1.05 log units) above the measured number, outside the stated range (below it).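

In this assay, replacing 4-chlorophenyl with 4-methoxyphenyl on the core of compound 3 gave a 3.7-fold lower number from compound 3 to compound 4 (0.57 log units; beyond the scatter), so on this core the number falls where on the core of compound 1 it rose. The same change therefore cannot be carried from one core to the other in this series as a fixed step, and not even its direction held: the same change on two cores in this assay, a 4.3-fold higher number (0.63 log units; beyond the scatter) from compound 1 to compound 2 and a 3.7-fold lower number (0.57 log units; beyond the scatter) from compound 3 to compound 4, 16-fold (1.20 log units) apart, beyond the scatter of two such steps. This does not show what reverses the step, since the difference between the two cores is not broken down here, and two pairs cannot tell which core, if either, represents the more usual behaviour of the change.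

Still open, from the compounds shown here alone, is how a core that carries only part of what separates compound 1 from compound 3 would respond to the same swap, which could help locate the part of the core that governs the direction. Also open, going by these compounds, is whether a fluoro group, a methyl group or an amine in the place of chloro would follow the rise seen on one core, the fall seen on the other, or neither.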